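The compounds below may be only part of what the source reports. "The series", "measured", "known", "first", "only" and "open" are said of these compounds alone.

Compound 1 `COc1ccc(/C=C/C(=O)c2ccncc2)cc1OC` carries two methoxy groups on its core. Going by the values given here, in an assay on cell membranes for inhibition of cytochrome P450 1A1 (Homo sapiens), read by fluorescence, using microsomes, with a stated time of 10 min (on this read-out higher numbers stand for weaker inhibition and lower numbers for stronger inhibition), compound 1 gives 380 nM, which places it at the low end of the two numbers measured so far, with the only other compound sitting within the scatter of it. That other compound is compound 2 `COc1cccc(/C=C/C(=O)c2ccncc2)c1`, which in this assay gives 590 nM; the step of a 1.6-fold higher number from compound 1 to compound 2 (0.19 log units; within the scatter) comes from hydrogen in place of a methoxy group on an aromatic carbon. Compound 3 `COc1ccc(/C=C/C(=O)c2ccncc2)cc1` has not yet been measured. It differs from compound 1 by hydrogen in place of methoxy on an aromatic carbon. Among the compounds with values here, only the step from compound 1 to compound 2 bears on this change: there, too, a methoxy group left the core and hydrogen took its place, and the number moved by a 1.6-fold higher number from compound 1 to compound 2 (0.19 log units; within the scatter), within the scatter. The group removed in compound 3 is a different one, the one ortho to a methoxy group and meta to a large group, so the two changes are not identical. Within the data shown here, still, on the one comparison at hand, no step beyond the scatter is expected in this assay from compound 1 to compound 3, with if anything a slightly higher number. Compound 3 is therefore estimated at 500 nM, between 250 nM and 1000 nM. This estimate means a step of a 1.3-fold higher number from compound 1 to compound 3 (0.12 log units; within the scatter), which is expected to stay within the scatter.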

Compound 3, half-maximal inhibitory concentration: 6310 nM
Estimate against measurement, compound 3: 13-fold (1.10 log units) below; measured number above the stated range.
By their numbers in this assay, from the lowest: compounds 1 and 2 (each within the scatter of the next); then compound 3.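

Replacing the methoxy group that sits ortho to a methoxy group and meta to a large group with hydrogen gives a 17-fold higher number from compound 1 to compound 3 (1.22 log units; beyond the scatter) in this assay and thus a large loss of inhibition. The same kind of swap at the other methoxy group of compound 1 gave only a 1.6-fold higher number from compound 1 to compound 2 (0.19 log units; within the scatter) and so the earlier pair had suggested a tolerance that does not extend to this position: in this assay the two methoxy groups of compound 1 do not count alike, and the outcome of the change depends on which of them leaves. Nothing at hand accounts for this difference between the two positions.

The compounds shown leave open whether the oxygen of the methoxy group or the whole group is what counts here, since a hydroxyl group, an ethoxy chain or a chlorine atom at this position would separate those readings. They also leave open whether this position matters as much when the other methoxy group is replaced by an amine or a fluorine atom, or when the pyridine-free parts of the shared core change.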